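Swapping Fluoro for Chloro: What Compound 4 Might Show

The source may report more compounds than this note shows. Statements on the series, on what has been measured and on what is new or still open speak of the compounds shown alone.

Measured compounds:
compound 1, `O=C(Cc1cccnc1)c1cc2cc(F)ccc2[nH]1`: 24%
compound 2, `O=C(Cc1cccnc1)c1cc2c(O)cccc2[nH]1`: "not active" (no number reported)
compound 3, `O=C(Cc1ccncc1)c1cc2ccccc2[nH]1`: "not active" (no number reported)

Of the compounds shown here, three sharing one core have been tested in an in vitro assay on P815B cells for inhibition of Indoleamine 2,3-dioxygenase 1 (Mus musculus), tested at 20 uM; a lower number here means less inhibition, a higher number more inhibition at the concentration tested (going by the name of the read-out). Going by the values given here, compound 1 gives 24% and is the only compound for which a number is reported at all. Compound 2 is reported in this assay as "not active" (no number reported), and compound 3 likewise as "not active" (no number reported), so neither of them offers a number to compare with. Among the compounds with values here, with no pair of measured compounds differing in a single place, there is no measured step to show how large a one-group change can be on this core.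

Compound 4, `O=C(Cc1cccnc1)c1cc2cc(Cl)ccc2[nH]1`, has not yet been measured. It differs from compound 1 in one place: chloro in place of fluoro on an aromatic carbon. Since nothing measured tells how this core responds to such an exchange, the expectation for the step from compound 1 to compound 4 is a number 6 percentage points higher from compound 1 to compound 4 (within the scatter), a small shift in this assay, within or barely beyond the scatter, leaning upward if anywhere. Compound 4 is therefore expected to give 30%, with a range from 10% to 52%.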

Compound 4, a percentage reported as inhibition, at one concentration (the size of the read-out at that concentration, not a potency): 24%
Compound 4: the middle estimate sits 6 percentage points above what was measured, and the stated range covers the measured number.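

In this assay, going by these compounds alone, chloro in place of fluoro on this aromatic carbon gives no change at the digits printed from compound 1 to compound 4 (within the scatter), and this is the first one-group step that can be read on the shared core. At the single concentration tested, the reading at this position therefore does not separate fluoro from chloro, though this is one pair on one core and supports no wider rule. No measurement shown bears on why the two groups read alike.

Still open, as far as these compounds go, is whether an amine, a methoxy group or a carboxylic acid on this same aromatic carbon would read differently from fluoro and chloro. Also open, from the compounds shown here alone, is how far a one-group change can move the reading elsewhere on the shared core; compound 2 and compound 3 carry no number to compare with.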